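The compounds below may be only part of what the source reports. "The series", "measured", "known", "first", "only" and "open" are said of these compounds alone.

Compound 1 `CC(C)OC(=O)N1CCC(COc2ccc(N3CCN(C(=O)N(C)C)CC3)nc2)CC1` gives only a limit in a functional assay on CHO-K1 cells for agonist activity at Glucose-dependent insulinotropic receptor (Homo sapiens), read by a luciferase reporter, with a stated time of 5 h (a higher number here means that more compound is needed for the effect, a lower number that less compound is needed), namely > 10000 nM, which is the limit of > 10000 nM in this assay, at which 1 of the 2 values shown sits. Among the measured compounds shown here, compound 2 `CCCS(=O)(=O)N1CCN(c2ccc(OCC3CCN(C(=O)CC(C)C)CC3)cn2)CC1` gives 1600 nM in this assay, the only number among the two values shown. Compound 3 `CCCS(=O)(=O)N1CCN(c2ccc(OCC3CCN(C(=O)C(F)F)CC3)cn2)CC1` has not yet been measured. Relative to compound 2 it carries difluoromethyl in place of isobutyl on a carbonyl carbon, and no step between measured compounds covers such an exchange. A modest weakening is expected, though a result within the usual scatter would not surprise. For compound 3 the estimate in this assay is 2500 nM, with a range from 800 nM to 8000 nM. This is expected to amount to a 1.6-fold higher number from compound 2 to compound 3 (0.19 log units; within the scatter).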

Compound 3, half-maximal effective concentration: 2100 nM
Estimate against measurement, compound 3: 1.2-fold (0.08 log units) above, and the stated range covers the measured number.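

In this assay the exchange of isobutyl for difluoromethyl on a carbonyl carbon gives a 1.3-fold higher number from compound 2 to compound 3 (0.12 log units; within the scatter) and so shows that this position accepts a group with fewer heavy atoms, carrying fluorine, without a change beyond the scatter. Both compound 2 and compound 3 give numbers here. Only compound 1 gives a limit: the limit of > 10000 nM in this assay, at which 1 of the 3 values shown sits. On these data alone, whether a longer chain, a phenyl ring or an amine on this carbonyl carbon would move the number remains open. One exchange also cannot show whether a single fluorine would behave like difluoromethyl.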